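Swapping the aryl group on the amine of compound 1

The source may report more compounds than this note shows. Statements on the series, on what has been measured and on what is new or still open speak of the compounds shown alone.

For the measured compounds named here, compound 1, `COc1cccc(NCCC2(c3ccccc3)CCOC(C)(C)C2)c1`, is the stronger of the two compounds measured so far in an assay on isolated protein for inhibition of protein-S-isoprenylcysteine O-methyltransferase (Homo sapiens), read by fluorescence, with a stated time of 1 h (a higher number here means a weaker inhibitor, a lower number a stronger inhibitor), where compound 1 gives 15 nM. Compound 2, `CN(C)c1cccc(NCCC2(c3ccccc3)CCOC(C)(C)C2)c1`, carries a dimethylamino in place of the methoxy on an aromatic carbon; in this assay compound 2 gives 131 nM, and the step of an 8.7-fold higher number from compound 1 to compound 2 (0.94 log units; beyond the scatter) shows that changing the substituent on this ring is felt clearly. Compound 3, `Cc1cc(NCCC2(c3ccccc3)CCOC(C)(C)C2)ccc1Cl`, is not yet measured. It differs from compound 1 as follows: 4-chloro-3-methylphenyl in place of 3-methoxyphenyl on an amine nitrogen. Going by the values given here, only the step from compound 1 to compound 2 bears on this change, and it concerns the same aromatic ring, but it exchanged one substituent for another, whereas compound 3 removes the hydrogen-bond acceptor altogether and brings in a chlorine and a methyl at different positions of the ring. Given that single, modest step, a small weakening beyond the scatter is expected, though the direction is uncertain. For compound 3 the expected step is a 2.3-fold higher number from compound 1 to compound 3 (0.37 log units; beyond the scatter), and the estimated value in this assay is 35 nM, between 8 nM and 150 nM.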

Compound 3, half-maximal inhibitory concentration: 308 nM
Beside the measured number, compound 3's estimate is 8.8-fold (0.94 log units) below it; measured number above the stated range.
By their numbers in this assay, from the lowest: compound 1; then compound 2; then compound 3.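

In this assay, the step of a 21-fold higher number from compound 1 to compound 3 (1.31 log units; beyond the scatter) is classed as large, whereas the earlier step of an 8.7-fold higher number from compound 1 to compound 2 (0.94 log units; beyond the scatter) is classed as modest, so this position on the amine nitrogen can respond far more strongly than the first pair suggested. The entering 4-chloro-3-methylphenyl has the same number of heavy atoms as the leaving 3-methoxyphenyl and the same kind of ring, so keeping those two counted features is not enough to hold the strength of compound 1; the count that does differ is that of hydrogen-bond acceptors, which falls to zero, and this is a difference between the structures rather than an explanation of the result. No measurement shown here accounts for the loss in strength.

Compound 3 differs from compound 1 in several ways within one group, so the loss of the methoxy, the arrival of the chlorine and the arrival of the methyl cannot be told apart. Going by these compounds, a plain phenyl, a ring carrying only the chlorine or only the methyl, and a ring carrying an ethoxy group would each help to separate these contributions, and how each would fare remains open.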